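The source may hold more compounds than are shown below. What is called first, only, known or untested is meant among the compounds shown, and "the series" means these compounds.

Measured in an ADME assay on HEK-293T cells (Homo sapiens) for cytotoxicity, read by MTT assay, with a stated time of 24 h; a lower number here means that less compound is tolerated, a higher number that more compound is tolerated:
Compound 1 `NC(=O)c1c(NC(=O)c2cnn3c(C(F)F)cc(-c4ccccc4)nc23)sc2c1CCC2` — > 250000 nM, a limit of the assay.
Compound 2 `NC(=O)c1c(NC(=O)c2cnn3c(C(F)F)cc(-c4ccccc4)nc23)sc2c1CCCC2` — > 250000 nM, a limit of the assay.

Among the measured compounds shown here, compound 2 stands at the limit of this assay, the only value known for it. Compound 1 also sits at that limit, as the evidence shows (the limit of > 250000 nM in this assay, at which 2 of the 2 values shown sit). Compound 3 `NC(=O)c1c(NC(=O)c2cnn3c(C(F)(F)F)cc(-c4ccccc4)nc23)sc2c1CCCC2` differs from compound 2 by fluoro in place of hydrogen on a saturated chain carbon bound to an aromatic carbon and two fluorine atoms, difluoromethyl to trifluoromethyl. For the measured compounds named here, no step between measured compounds is available to guide the expectation. In this assay the expected step is a step that the limit leaves unreadable from compound 2 to compound 3, none beyond the scatter. Compound 3 is therefore estimated at 300000 nM, within 150000 nM to 600000 nM, most likely reported again only as a limit.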

Compound 3, half-maximal cytotoxic concentration: > 250000 nM
Compound 3 was reported as a limit (the forecaster's own chance of this, stated with the estimate: 85%); the middle value is on the limit's open side.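

Compound 3, like compound 2, is reported only as a limit, so no step between these two compounds can be read: the limit of > 250000 nM in this assay, at which 3 of the 3 values shown sit.

The compounds shown leave open whether difluoromethyl and trifluoromethyl differ in how much compound is tolerated.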